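A Methyl Added to the Pyridinyl Group of Compound 2

The compounds below may be only part of what the source reports. "The series", "measured", "known", "first", "only" and "open" are said of these compounds alone.

- compound 1 `Nc1ccc(S(=O)(=O)N2CCN(c3ncc(C(O)(C(F)(F)F)C(F)(F)F)cc3C#CC3CC3)CC2)cn1`: 67 mL.min-1.g-1
- compound 2 `Nc1ccc(S(=O)(=O)N2CCN(c3ncc(C(O)(C(F)(F)F)C(F)(F)F)cc3-c3cccnc3)CC2)cn1`: 20 mL.min-1.g-1

Of the compounds shown here, two have been measured in an ADME assay (liver) for metabolic stability, with Liver microsome (Rattus norvegicus) as the target, using microsomes and NADPH, with a stated time of 30 min, tested at 1 uM (a lower number here means slower removal, a higher number faster removal of the compound), and compound 2, at 20 mL.min-1.g-1, holds the lower number of the pair. The next compound, compound 3 `Cc1ccc(-c2cc(C(O)(C(F)(F)F)C(F)(F)F)cnc2N2CCN(S(=O)(=O)c3ccc(N)nc3)CC2)cn1`, keeps everything in compound 2 but one detail: methyl in place of hydrogen on an aromatic carbon. The pyridin-3-yl group of compound 2 thus becomes 6-methylpyridin-3-yl in compound 3.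

Within the data shown here, only one measured step bears on this change, and it does so indirectly. That step, a 3.4-fold lower number from compound 1 to compound 2 (0.53 log units; beyond the scatter), replaced 2-cyclopropylethynyl with pyridin-3-yl at the same place on the shared core. Among the measured compounds shown here, it says nothing directly about a methyl on the pyridin-3-yl group, and no measured pair shows that exact change. The new change is much smaller than the exchange of one whole group for another, so a step of that size is not expected here. In this assay, no step beyond the usual scatter is expected. For compound 3 the estimated value is 24 mL.min-1.g-1, with an expected range of 12 mL.min-1.g-1 to 48 mL.min-1.g-1. This estimate corresponds to an expected 1.2-fold higher number from compound 2 to compound 3 (0.08 log units; within the scatter).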

Compound 3, intrinsic clearance in microsomes: 182 mL.min-1.g-1
Estimate against measurement, compound 3: 7.6-fold (0.88 log units) below; the measured number lies above the stated range.
By their numbers in this assay, from the lowest: compound 2; then compound 1; then compound 3.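

In this assay, a single methyl on the pyridin-3-yl group moves the number a long way, a 9.1-fold higher number from compound 2 to compound 3 (0.96 log units; beyond the scatter), so this aromatic carbon, next to the ring nitrogen and para to a large group, is a place where even one added carbon counts. The advantage that pyridin-3-yl held over 2-cyclopropylethynyl does not carry over to 6-methylpyridin-3-yl, which lands on the far side of 2-cyclopropylethynyl, with a 2.7-fold higher number from compound 1 to compound 3 (0.43 log units; beyond the scatter). Among these three compounds, then, a pyridine ring at this place on the shared core does not by itself keep the number low, and the low reading belongs to the form without the methyl.

Nothing available here bears on why one methyl has so large an effect. The compounds shown leave open whether the rise is particular to methyl or would also come with a fluorine, a methoxy group or an amine on the same aromatic carbon, and whether a methyl elsewhere on the ring would give a similar step.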